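From Fluoro to Chloro: Expecting the Number for Compound 4

The compounds below may be only part of what the source reports. "The series", "measured", "known", "first", "only" and "open" are said of these compounds alone.

Among the measured compounds shown here, compound 2 `C/C(=N/NC(=S)Nc1ccccc1F)c1ccccn1` is one of three compounds measured in a functional assay on MCF7 cells (Homo sapiens) for cytotoxicity, read by MTT assay, with a stated time of 48 h (on this read-out higher numbers stand for weaker inhibition and lower numbers for stronger inhibition), a test of how strongly a compound holds back the growth of cultured breast-cancer cells. In this assay compound 2 gives 0.39 nM. Compound 1 `CC(=NNC(=S)Nc1ccccc1F)c1ccccn1` has the same atoms and bonds, and in this assay compound 1 gives 0.39 nM; the step of no change at the digits printed from compound 1 to compound 2 (within the scatter) sits alongside (the fact that one of compounds 1 and 2 is drawn with a defined configuration and the other without, at the place where they differ). Compound 3 `CC(=NNC(=S)Nc1ccccc1)c1ccccn1` carries hydrogen in place of fluoro on an aromatic carbon, and in this assay compound 3 gives 0.18 nM, so that a 2.2-fold lower number from compound 1 to compound 3 (0.34 log units; beyond the scatter). Compound 2 therefore stands level with compound 1 at the highest number of the three, with compound 3 the only one clearly lower.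

Compound 4 `C/C(=N/NC(=S)Nc1ccccc1Cl)c1ccccn1` has not yet been measured. It differs from compound 2 by chloro in place of fluoro on an aromatic carbon. For the measured compounds named here, no measured step swaps one halogen for another at this place. The nearest guide is a 2.2-fold lower number from compound 1 to compound 3 (0.34 log units; beyond the scatter), a modest shift when the fluoro is taken away altogether, while no change at the digits printed from compound 1 to compound 2 (within the scatter) shows no movement at all. Replacing fluoro with chloro is therefore expected to move the number little, if at all, and the step of a 1.0-fold higher number from compound 2 to compound 4 (0.01 log units; within the scatter) is expected to stay within the scatter. Compound 4 is estimated at 0.4 nM, with a range from 0.15 nM to 1.1 nM.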

Compound 4, half-maximal inhibitory concentration: 0.16 nM
Compound 4: the middle estimate sits 2.5-fold (0.40 log units) above what was measured, and the stated range covers the measured number.
By their numbers in this assay, from the lowest: compounds 4 and 3 (each within the scatter of the next); then compounds 1 and 2 (each within the scatter of the next).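

In this assay the exchange of fluoro for chloro gives a 2.4-fold lower number from compound 2 to compound 4 (0.39 log units; beyond the scatter), a modest step toward stronger inhibition on this read-out. Among the compounds shown here, until now the only change at this place that moved the number was the loss of the fluoro, a 2.2-fold lower number from compound 1 to compound 3 (0.34 log units; beyond the scatter), which left open whether any halogen here would hold the number up; compound 4 keeps a halogen on the same aromatic carbon and its number still falls, so the identity of the group matters and not only whether a group is present. Nothing at hand explains why these two halogens give different numbers at this place.

Going by these compounds, whether a bromo or a methoxy group on the same aromatic carbon would give a number closer to that of compound 2 or that of compound 4 stays open. The compounds shown also include no pair whose only difference is chloro against hydrogen, so those two groups cannot be ranked against each other at this place.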